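Naphthalene amide from a weak bromophenyl benzyl ether

This account rests on a few compounds, and the source may have more. Where it says the series, first, only, none or still open, it means among the compounds named here.

Of the compounds shown here, three have been measured in a functional assay on SK-BR-3 cells (Homo sapiens) for antiproliferative activity, read by MTT assay, with a stated time of 48 h; on this read-out lower numbers stand for stronger inhibition and higher numbers for weaker inhibition. Compound 1 `Cc1ccc(C(F)(F)F)cc1COc1cc(NC(=O)c2ccc(I)cc2)ccc1N(C)S(C)(=O)=O` gives 3500 nM. Compound 2 `COc1ccc(OC)c(COc2cc(NC(=O)c3ccc(Br)cc3)ccc2N(C)S(=O)(=O)C(F)(F)F)c1` gives 470 nM. Compound 3 `Cc1ccc(C)c(COc2cc(NC(=O)c3ccc(Br)cc3)ccc2N(C)S(=O)(=O)C(F)(F)F)c1` gives 36400 nM, the highest of the three numbers, and thus the weakest inhibitor measured, beyond the scatter against both others. Within the data shown here, the one single-point step among them, a 77-fold higher number from compound 2 to compound 3 (1.89 log units; beyond the scatter), concerns the benzyl ether and not the amide.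

Compound 4 `Cc1ccc(C)c(COc2cc(NC(=O)c3ccc4ccccc4c3)ccc2N(C)S(=O)(=O)C(F)(F)F)c1` differs from compound 3 only at the amide: naphthalen-2-yl in place of 4-bromophenyl on a carbonyl carbon. Among the measured compounds shown here, no measured step touches the aryl group on the carbonyl carbon; compound 1 carries a different halogen there but also differs elsewhere, so its value of 3500 nM cannot be read as a step. With no guidance, a change of little size, or none beyond the scatter, in this assay is expected for the step of a 1.8-fold lower number from compound 3 to compound 4 (0.26 log units; within the scatter). Compound 4 is therefore estimated at 20000 nM, with a range from 4000 nM to 90000 nM.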

Compound 4, half-maximal inhibitory concentration: 41400 nM
Beside the measured number, compound 4's estimate is 2.1-fold (0.32 log units) below it, and the stated range covers the measured number.
By their numbers in this assay, from the lowest: compound 2; then compound 1; then compounds 3 and 4 (each within the scatter of the next).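

In this assay, among these compounds, naphthalen-2-yl in place of 4-bromophenyl on the carbonyl carbon gives a 1.1-fold higher number from compound 3 to compound 4 (0.06 log units; within the scatter), the first measured step at this position. With the 2,5-dimethylphenyl ether held fixed, the aryl group on the carbonyl carbon can thus go from one six-membered aromatic ring of carbon only, bearing bromine, to two such rings with no difference beyond the scatter. No available evidence bears on why the two amides read alike.

The compounds shown leave open whether the same exchange on the 2,5-dimethoxyphenyl ether of compound 2, at 470 nM, would also read alike. Also open, on these data alone, is what a pyridin-3-yl ring or a 4-carboxyphenyl group would give on the carbonyl carbon.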